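Aryl Urea Swap at the Weak End of Potency

A few compounds are considered here, and "the series" means these few. Any claim that something is new, unique, unknown or untested is made for them only; others in the source may bear on it.

The set rests on three measured compounds. Compound 1 `COc1ccc(NC(=O)Nc2cccc(CNc3ncnc4ccccc34)c2)cc1` is read in a functional assay on HepG2 cells (Homo sapiens) for antiproliferative activity, read by MTT assay (a lower number here means a stronger inhibitor, a higher number a weaker inhibitor), where compound 1 reaches only the limit of the assay, > 50000 nM. Compound 2 `O=C(Nc1cccc(CNc2ncnc3ccccc23)c1)Nc1cccc(C(F)(F)F)c1` gives 40000 nM in this assay, and the step of an at least 1.2-fold lower number from compound 1 to compound 2 (0.09 log units; that floor lies within the scatter) does not rise above the scatter. Compound 3 `COc1cc2ncnc(NCc3cccc(NC(=O)Nc4ccccc4C)c3)c2cc1OC` is also a limit case: in this assay compound 3 gives > 50000 nM, a limit of the assay and not a number. That leaves compound 3 standing at the weak end, with two of the three values stuck at the same floor (the limit of > 50000 nM in this assay, at which 2 of the 3 values shown sit).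

Compound 4 `COc1cc2ncnc(NCc3cccc(NC(=O)Nc4ccc(F)cc4)c3)c2cc1OC` differs from compound 3 in one place: 4-fluorophenyl in place of 2-methylphenyl on an amide-type nitrogen. Going by the values given here, no measured step covers this exact change. Among the compounds with values here, the only step available on the urea aryl group, an at least 1.2-fold lower number from compound 1 to compound 2 (0.09 log units; that floor lies within the scatter), was small enough to sit within the scatter, so there is no ground to expect a strong effect here either, in either direction. Compound 4 is therefore expected to remain near the floor, with the estimated step of a number no higher from compound 3 to compound 4 (the limit leaves the size open) not beyond the scatter. Compound 4 is estimated at 50000 nM, within a range from 25000 nM to 100000 nM, and a further limit rather than a number is the more likely outcome.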

Compound 4, half-maximal inhibitory concentration: 36600 nM
Compound 4: the middle estimate sits 1.4-fold (0.14 log units) above what was measured; low and high end bracket the measured number.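

In this assay, going by these compounds alone, 4-fluorophenyl in place of 2-methylphenyl on the amide-type nitrogen gives an at least 1.3-fold lower number from compound 3 to compound 4 (0.13 log units; that floor lies within the scatter) and so provides the first actual number on the shared core of compound 3 and compound 4. Going by these compounds, this step cannot show a real gain, since its floor stays within the scatter and its true size remains open, but it does repeat what was seen for compound 1 and compound 2: a change to the aryl group on the urea replaces a limit with a number, and the number stays at the weak end. Across the set, the read-out therefore remains crowded against the same boundary, so that neither aryl change yet separates clearly from the rest: the limit of > 50000 nM in this assay, at which 2 of the 4 values shown sit.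

On these data alone, it remains open how compound 3 would read if it gave a number rather than a limit, and whether 4-fluorophenyl would behave the same way on the core of compound 1. As far as these compounds go, it is also open whether an aryl group carrying a carboxylic acid or a dimethylamino group at this nitrogen would move the read-out clear of this weak end.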